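This account rests on a few compounds, and the source may have more. Where it says the series, first, only, none or still open, it means among the compounds named here.

In an ADME assay on a cell-free system (plasma, Homo sapiens) for protein binding, three compounds have been measured on a shared core. Compound 1 `CNc1nccc(N2CC[C@H](NC(=O)Nc3ccc(CN(C)C)c(C(F)(F)F)c3)C2)n1` gives 94.3% and compound 3 `CNc1nccc(N2CC[C@H](NC(=O)Nc3ccc(OC(F)(F)F)cc3)C2)n1` gives 97.7% in this read-out. Compound 2 `CNc1nccc(N2CC[C@H](NC(=O)Nc3ccc(Cl)c(C(F)(F)F)c3)C2)n1` gives 99.8% and so has the lowest unbound fraction of the three. Compound 4 `Nc1nccc(N2CC[C@H](NC(=O)Nc3ccc(Cl)c(C(F)(F)F)c3)C2)n1` differs from compound 2 at one place (hydrogen in place of methyl on a nitrogen on an aromatic ring), with hydrogen in place of methyl on a nitrogen on an aromatic ring, turning methylamino into amino. Within the data shown here, no measured pair tests this change. Among the measured compounds shown here, the one measured step at a single place is a 29-fold lower unbound fraction from compound 1 to compound 2 (1.45 log units; beyond the scatter) and it came with chloro in place of (dimethylamino)methyl, a different change. It shows how far the unbound fraction can move in this set, but it gives no direction here. With so small a change, only a slight shift is expected. Compound 2 at 99.8% already lies near the top of the scale, so any move is expected toward more free compound. The expected move is a 1.5-fold higher unbound fraction from compound 2 to compound 4 (0.18 log units; within the scatter) and that stays within the usual scatter. Compound 4 is estimated at 99.7% with a range from 99% to 99.9% as the expected span.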

Compound 4, plasma protein binding: 99.5%
Beside the measured number, compound 4's estimate is 1.7-fold (0.22 log units) (unbound fraction) below it, and the stated range covers the measured number.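

In this assay, taking the methyl off the nitrogen on an aromatic ring gives a 2.5-fold higher unbound fraction from compound 2 to compound 4 (0.40 log units; beyond the scatter), so this position also moves the read-out beyond the usual scatter. The group that leaves is a single carbon with no net charge, and the step is modest, much smaller than a 29-fold lower unbound fraction from compound 1 to compound 2 (1.45 log units; beyond the scatter) at the other changed place. No measurement at hand explains why this small change shifts the unbound fraction.

On these data alone, whether ethyl or a longer chain on this nitrogen would shift the unbound fraction the other way remains open. As far as these compounds go, this step also rests on one pair of compounds carrying chloro, so it is unknown whether the same change would give a similar step with (dimethylamino)methyl in that place.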